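The source may report more compounds than this note shows. Statements on the series, on what has been measured and on what is new or still open speak of the compounds shown alone.

Three related compounds have been tested so far in an ADME assay on MT4 cells (Homo sapiens) for cytotoxicity, read by MTT assay, with a stated time of 4 days (a lower number here means that less compound is tolerated, a higher number that more compound is tolerated), to date. Compound 1 (`CCCN(C)c1nc(Cc2c(F)cccc2F)c(C)c(=O)[nH]1`) gives > 81000 nM as a limit of the assay, not as a number. Compound 2 (`CCCN(C)c1nc(C(C)c2c(F)cccc2F)cc(=O)[nH]1`) gives > 81000 nM as a limit too. Compound 3 (`CCN(C)c1nc(C(C)c2c(F)cccc2F)c(C)c(=O)[nH]1`) gives 81000 nM as a real number, the only one of the three.

Compound 4 (`CCCN(C)c1nc(C(C)c2c(F)cccc2F)c(C)c(=O)[nH]1`) has not been measured yet. It differs from compound 3 in one place (methyl in place of hydrogen on a saturated chain carbon, two bonds along the chain from a nitrogen on an aromatic ring): methyl in place of hydrogen on a saturated chain carbon, two bonds along the chain from a nitrogen on an aromatic ring, so that ethyl(methyl)amino becomes methyl(propyl)amino.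

Among the compounds with values here, no two measured compounds differ in one place alone, so no direct step can serve as a guide. Compound 1 and compound 2 already carry methyl(propyl)amino, but what they offer is the limit of > 81000 nM in this assay, at which 2 of the 3 values shown sit, and no number to compare. Compound 3 stands at 81000 nM in the same region, so no shift beyond the usual scatter is expected. The expected change is a 1.2-fold lower number from compound 3 to compound 4 (0.06 log units; within the scatter) as an estimate. A report as a limit alone would be no surprise. For compound 4 the estimated value is 70000 nM with an expected range from 35000 nM to 110000 nM in this measurement.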

Compound 4, half-maximal cytotoxic concentration: > 78000 nM
Compound 4: no number, only a limit; the forecaster's own chance of this, stated with the estimate: 45%; middle value at least 1.1-fold (0.04 log units) away from the limit.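

Within the data shown here, compound 4 is reported only as a limit, and no step to it can be read from compound 1, compound 2 or compound 3. The compounds shown leave open how much of compound 1, compound 2 or compound 4 is tolerated in this assay, and whether any single change among them shifts that number.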